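Removing one hydroxyethyl arm from a weak quinoline urea

The source may report more compounds than this note shows. Statements on the series, on what has been measured and on what is new or still open speak of the compounds shown alone.

The study covers compound 1 `COc1cc(NC(C)CCCNC(=O)NNC(=O)N(CCO)CCO)c2ncccc2c1` and compound 2 `O=C(NC(c1ccccc1)c1ccc(Cl)cc1)NC(c1ccccc1)c1ccc(Cl)cc1`, both tested in a functional assay on L1210 cells (Mus musculus) for inhibition, read by MTT assay, with a stated time of 4 days; on this read-out higher numbers stand for weaker inhibition and lower numbers for stronger inhibition. Compound 1 reaches only the limit of this assay, reported as > 250000 nM, so no number is known for it; this is the point at which compound 1 stands, (the limit of > 250000 nM in this assay, at which 1 of the 2 values shown sits). Compound 2 gives 250000 nM in this assay. Among the compounds with values here, no step between these two can be measured, since compound 1 carries a limit rather than a value. The change to compound 3 `COc1cc(NC(C)CCCNC(=O)NNC(=O)NCCO)c2ncccc2c1` is hydrogen in place of 2-hydroxyethyl on an amide-type nitrogen, cut one bond further out a move from bis(2-hydroxyethyl)carbamoyl to (2-hydroxyethyl)carbamoyl. With compound 1 sitting at the limit, no step beyond the scatter is expected from compound 1 to compound 3, and the shift expected for this assay is a number no higher from compound 1 to compound 3 (the limit leaves the size open). Compound 3 is therefore estimated at 250000 nM, within 100000 nM to 600000 nM, very likely again only a limit.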

Compound 3, half-maximal inhibitory concentration: > 250000 nM
Compound 3: no number, only a limit; the forecaster's own chance of this, stated with the estimate: 70%; the middle value lies on the limit itself.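

In this assay compound 3 gives > 250000 nM, which is a limit and not a number. Within the data shown here, compound 1 also stands at a limit, so no step from it to compound 3 can be read. The compounds shown leave open whether hydrogen in place of 2-hydroxyethyl changes inhibition at all.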